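The source may hold more compounds than are shown below. What is called first, only, known or untested is meant among the compounds shown, and "the series" means these compounds.

In a functional assay on thoracic aorta (Rattus norvegicus, strain Wistar), with a stated time of 15 min (on this read-out lower numbers stand for an effect already at smaller amounts and higher numbers for an effect only at larger amounts of compound), two compounds have been measured so far. Compound 1, with the structure `CC(C)Oc1ccc(Br)cc1C(C)NC(=O)N(C)S(=O)(=O)c1ccccc1`, gives 32100 nM. Compound 2, with the structure `COc1ccc(Br)cc1C(C)NC(=O)N(C)S(=O)(=O)c1ccc(C)cc1`, gives 19100 nM. These two numbers sit within the usual scatter of repeated measurements of this kind, so the data do not separate compound 2 from compound 1. For the measured compounds named here, no pair of measured compounds differs in a single place, so there is no measured step to lean on.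

Compound 3, with the structure `COc1ccc(Br)cc1C(C)NC(=O)N(C)S(=O)(=O)c1ccccc1`, has not yet been measured. It differs from compound 2 in one place: hydrogen in place of methyl on an aromatic carbon. Going by the values given here, compound 1 also carries a phenyl in place of the 4-methylphenyl, but it differs from compound 3 in a second place as well, so the value of compound 1, 32100 nM, shows only that a compound of this kind can still fall in the same region as compound 2. Given that, the step of a 1.3-fold higher number from compound 2 to compound 3 (0.12 log units; within the scatter) is expected to be small, in either direction, and not beyond the scatter. Compound 3 is therefore expected to give about 25000 nM, with a range from 10000 nM to 60000 nM.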

Compound 3, half-maximal effective concentration: 16800 nM
For compound 3 the middle estimate is 1.5-fold (0.17 log units) above the measured one, and the stated range covers the measured number.
By their numbers in this assay, from the lowest: compounds 3, 2 and 1 (each within the scatter of the next).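

Compounds that differ in one place can now be compared directly. In this assay, hydrogen in place of methyl on the aromatic carbon, the change from 4-methylphenyl to phenyl, gives a 1.1-fold lower number from compound 2 to compound 3 (0.06 log units; within the scatter), so this read-out does not distinguish a methyl from a hydrogen at this position; methyl in place of isopropyl on the oxygen gives a 1.9-fold lower number from compound 1 to compound 3 (0.28 log units; within the scatter), so the two groups on the oxygen are not told apart either, and neither single change gives a measurable shift among these three compounds. Nothing available here offers an explanation for either step, small as both are.

As far as these compounds go, these comparisons cover only hydrogen and methyl at the aromatic carbon and only methyl and isopropyl on the oxygen, so it remains open whether an amine or a carboxylic acid at that aromatic carbon, or a longer chain on the oxygen, would move the number beyond the scatter. From the compounds shown here alone, the bromine is the same in all three compounds, so what it contributes, and what would follow from replacing it with chlorine or hydrogen, also remains open.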